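Swapping the Benzodioxin for a Trifluoromethoxyphenyl Group

This account rests on a few compounds, and the source may have more. Where it says the series, first, only, none or still open, it means among the compounds named here.

In an ADME assay on HEK293 cells (Homo sapiens) for cytotoxicity, read by CellTiter-Glo and resazurin assay, with a stated time of 72 h (on this read-out higher numbers stand for an effect only at larger amounts of compound and lower numbers for an effect already at smaller amounts), compound 1 `CCOC(=O)CCCCCOc1cccc(CN(C(=O)c2ccc(-c3ccncc3)cc2)C(C)C)c1`, compound 2 `CCOC(=O)CCCCCOc1cccc(CN(C(=O)c2ccc(-c3cnc(OC)nc3OC)cc2)C(C)C)c1` and compound 3 `CCOC(=O)CCCCCOc1cccc(CN(C(=O)c2ccc(-c3ccc4c(c3)OCCO4)cc2)C(C)C)c1` share one core and differ only in the aromatic group at its far end. Compound 1 gives > 26000 nM, which is a limit of the assay rather than a number. Compound 2 likewise gives > 26000 nM, again a limit. Compound 3 gives > 24400 nM, also a limit. Its standing can thus be told only as sitting at the limit of > 24400 nM in this assay, at which 1 of the 3 values shown sits, while the other two sit at the limit of > 26000 nM in this assay, at which 2 of the 3 values shown sit. The steps a step that the two limits leave unreadable from compound 1 to compound 2, a step that the two limits leave unreadable from compound 1 to compound 3 and a step that the two limits leave unreadable from compound 2 to compound 3 therefore have no readable size. Compound 4 `CCOC(=O)CCCCCOc1cccc(CN(C(=O)c2ccc(-c3cccc(OC(F)(F)F)c3)cc2)C(C)C)c1` differs from compound 3 by 3-(trifluoromethoxy)phenyl in place of 2,3-dihydro-1,4-benzodioxin-6-yl on an aromatic carbon. Since every measured exchange at this position left the read-out at a limit, no step beyond the scatter is expected for a step that the limit leaves unreadable from compound 3 to compound 4. Compound 4 is expected to return 26000 nM, between 10000 nM and 80000 nM, most likely once more as a limit.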

Compound 4, half-maximal effective concentration: > 26000 nM
Compound 4 ended at the assay's limit (the forecaster's own chance of this, stated with the estimate: 85%); the middle value lies on the limit itself.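

Compound 4 also ends at a limit of the assay, so its steps from compound 1, compound 2 and compound 3 cannot be read. The compounds shown leave open at what amount any of these four would show an effect in this assay, and whether the far-end aromatic group changes that amount.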